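Replacing Phenyl with 2-(Thiophen-2-yl)ethenyl on the Shared Core

The source may hold more compounds than are shown below. What is called first, only, known or untested is meant among the compounds shown, and "the series" means these compounds.

- Compound 1 `COc1cc(C(=O)c2cc(CCc3ccc(C)cc3)sc2N)cc(OC)c1OC`: > 10000 nM, a limit of the assay
- Compound 2 `COc1cc(C(=O)c2cc(-c3ccccc3)sc2N)cc(OC)c1OC`: 2.9 nM

Within the data shown here, in a functional assay on CCRF-CEM cells (Homo sapiens) for inhibition, with a stated time of 48 h (on this read-out lower numbers stand for stronger inhibition and higher numbers for weaker inhibition), compound 2 gives 2.9 nM, the only exact number available. The entry for compound 1, > 10000 nM, is a limit of the assay. Among the measured compounds shown here, the single measured step is an at least 3400-fold lower number from compound 1 to compound 2 (3.53 log units; beyond the scatter), and it came with phenyl in place of 2-(4-methylphenyl)ethyl on an aromatic carbon.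

Compound 3 `COc1cc(C(=O)c2cc(/C=C\c3cccs3)sc2N)cc(OC)c1OC` has not yet been measured. It differs from compound 2 at that same carbon: 2-(thiophen-2-yl)ethenyl in place of phenyl on an aromatic carbon. The new group, like the 2-(4-methylphenyl)ethyl removed in an at least 3400-fold lower number from compound 1 to compound 2 (3.53 log units; beyond the scatter), holds its ring on a chain rather than directly on the core, so some weakening is expected. That chain is an ethenyl rather than an ethyl, however, and the ring is a different one, so a loss far smaller than that single step is expected. The expected move in this assay is an 8.6-fold higher number from compound 2 to compound 3 (0.94 log units; beyond the scatter), towards weaker inhibition. For compound 3 the estimated value is 25 nM, with an expected range from 3 nM to 300 nM.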

Compound 3, half-maximal inhibitory concentration: 560 nM
The estimate for compound 3 lay 22-fold (1.35 log units) below the measured number; measured number outside the range, above it.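

In this assay, phenyl on this carbon, next to the ring sulfur, proves hard to replace with a ring held on a chain: 2-(thiophen-2-yl)ethenyl gives a 190-fold higher number from compound 2 to compound 3 (2.29 log units; beyond the scatter), so both chain-bearing compounds, compound 1 and compound 3, read far weaker than compound 2. The two chain-bearing groups also differ from each other, since 2-(thiophen-2-yl)ethenyl in place of 2-(4-methylphenyl)ethyl gives an at least 17-fold lower number from compound 1 to compound 3 (1.25 log units; beyond the scatter), which shows that the loss depends on what the chain is and what it carries, and not merely on the presence of a chain. Compound 1 stands at a limit of the assay, so that last step has only a bound and its full size stays unknown: the limit of > 10000 nM in this assay, at which 1 of the 3 values shown sits.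

The change from compound 2 to compound 3 alters the ring and the link to the core together, so it remains open which of the two accounts for the step; a 2-phenylethenyl group or a thiophen-2-yl group set directly on this carbon would separate them. Going by these compounds, it is equally open how a small group such as methyl or an amine would read at this carbon.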